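The compounds below may be only part of what the source reports. "The series", "measured", "known", "first", "only" and "open" are said of these compounds alone.

Working notes on the series in a functional assay on MDA-MB-231 cells (Homo sapiens) for cytotoxicity, read by MTT assay, with a stated time of 72 h; a higher number here means that more compound is needed for the effect, a lower number that less compound is needed. Three compounds on the shared core are measured, all differing only at the oxygen on the saturated carbon. Compound 1 `CCc1cccc2c(OC)c(-c3occ(C)c3CO)ccc12` returns only a limit, > 10 ug/mL, that is the limit of > 10 ug/mL in this assay, at which 1 of the 3 values shown sits. Compound 2 `CCc1cccc2c(OC)c(-c3occ(C)c3COCC(F)(F)F)ccc12` gives 5.3 ug/mL. Compound 3 `CCc1cccc2c(OC)c(-c3occ(C)c3COC(C)=O)ccc12` gives 3.5 ug/mL, the lower of the two numbers, though the step of a 1.5-fold lower number from compound 2 to compound 3 (0.18 log units; within the scatter) lies within the scatter, so no order between compound 2 and compound 3 is claimed. The steps of an at least 1.8-fold lower number from compound 1 to compound 2 (0.27 log units; that floor lies within the scatter) and an at least 2.8-fold lower number from compound 1 to compound 3 (0.45 log units; beyond the scatter) each start from a limit and set only a floor.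

Compound 4 `CCc1cccc2c(OC)c(-c3occ(C)c3COC(=O)CCN(CC)CC)ccc12` differs from compound 3 by (diethylamino)methyl in place of hydrogen on a saturated chain carbon bound to a carbonyl carbon. Among the compounds with values here, none of the measured steps lengthens the acyl chain; the nearest evidence is the step of a 1.5-fold lower number from compound 2 to compound 3 (0.18 log units; within the scatter), which shows that exchanging one ester-side group for another moved the number only within the scatter. The step of no change at the digits printed from compound 3 to compound 4 (within the scatter) is therefore expected to stay within the scatter, in no firm direction. For compound 4 the estimate is 3.5 ug/mL, with a range from 1.5 ug/mL to 9 ug/mL.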

Compound 4, concentration for half-maximal effect: 1.7 ug/mL
The estimate for compound 4 lay 2.1-fold (0.31 log units) above the measured number; the measured number falls inside the stated range.
By their numbers in this assay, from the lowest: compound 4; then compounds 3 and 2 (each within the scatter of the next). At a limit, above all of these: compound 1.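

In this assay, the step of a 2.1-fold lower number from compound 3 to compound 4 (0.31 log units; beyond the scatter) extends the acyl chain with (diethylamino)methyl on a saturated chain carbon bound to a carbonyl carbon, and unlike the exchange of acetyl for 2,2,2-trifluoroethyl, it lies beyond the scatter. The step of a 3.1-fold lower number from compound 2 to compound 4 (0.49 log units; beyond the scatter) also lies beyond the scatter, so the oxygen on the saturated carbon accepts this larger group and compound 4 now holds the lowest number among the measured values. Compound 1 stands at a limit, so the step of an at least 5.8-fold lower number from compound 1 to compound 4 (0.76 log units; beyond the scatter) sets only a floor: the limit of > 10 ug/mL in this assay, at which 1 of the 4 values shown sits.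

As far as these compounds go, it remains open whether the step depends on the amine or on the added chain alone, which a plain carbon chain of similar length would separate. From the compounds shown here alone, how a smaller amine such as dimethylamino, or a carboxylic acid at the chain end, would read also stays open.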